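Pyrrolidinyl for Dimethylamino on an Acrylamide Side Chain

The compounds below may be only part of what the source reports. "The series", "measured", "known", "first", "only" and "open" are said of these compounds alone.

Measured compounds in a functional assay on PC-3 cells (Homo sapiens) for antiproliferative activity, read by MTT assay, with a stated time of 72 h; a higher number here means a weaker inhibitor, a lower number a stronger inhibitor:
compound 1 `C/C=C/C(=O)Nc1cc2c(N3CCCc4ccccc43)ncnc2cc1O[C@@H]1CCOC1`, 9350 nM
compound 2 `CN(C)C/C=C/C(=O)Nc1cc2c(N3CCCc4ccccc43)ncnc2cc1O[C@@H]1CCOC1`, 4170 nM

Going by the values given here, compound 2 gives the lowest of the two numbers in this assay; its only neighbour is compound 1, and the step of a 2.2-fold lower number from compound 1 to compound 2 (0.35 log units; beyond the scatter) is modest but beyond the scatter. That step concerns dimethylamino in place of hydrogen on a saturated chain carbon bound to a double-bonded chain carbon.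

Compound 3 `O=C(/C=C/CN1CCCC1)Nc1cc2c(N3CCCc4ccccc43)ncnc2cc1O[C@@H]1CCOC1` is not yet measured. It differs from compound 2 by pyrrolidin-1-yl in place of dimethylamino on a saturated chain carbon bound to a double-bonded chain carbon. No measured step covers a change of this kind: the only step shown swaps hydrogen for a basic group, while here one basic group replaces another of the same sort, each carrying one hydrogen-bond acceptor and no charge. The expectation therefore rests on the assumption that such a swap changes little, so the step of a 1.2-fold lower number from compound 2 to compound 3 (0.08 log units; within the scatter) is expected to stay within the scatter. Compound 3 is estimated at 3500 nM in this assay, with a range from 1500 nM to 9000 nM.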

Compound 3, half-maximal inhibitory concentration: 5780 nM
Compound 3: middle estimate off by 1.7-fold (0.22 log units), on the low side; the range from low to high includes it.
By their numbers in this assay, from the lowest: compounds 2, 3 and 1 (each within the scatter of the next, the first and the last beyond it).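

In this assay, putting pyrrolidin-1-yl in place of dimethylamino on the saturated chain carbon gives a 1.4-fold higher number from compound 2 to compound 3 (0.14 log units; within the scatter), so a group of 5 heavy atoms with a five-membered non-aromatic ring sits at this position where 3 heavy atoms and no ring sat before, with no difference that can be told apart from the ordinary spread of repeated measurements. Set against the compound with hydrogen at this position, the same group gives a 1.6-fold lower number from compound 1 to compound 3 (0.21 log units; within the scatter), whereas dimethylamino did clear the scatter in that comparison, so with these three compounds the modest advantage over hydrogen cannot be said to extend to pyrrolidin-1-yl. Nothing measured here offers an explanation for either step.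

Still open, from the compounds shown here alone, is whether a six-membered ring amine such as piperidin-1-yl or morpholin-4-yl, or a longer chain carrying the amine, would move the number in this assay beyond the scatter in either direction. Also open, going by these compounds, is whether the closeness of dimethylamino and pyrrolidin-1-yl would hold on a different core.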